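A Methoxy Group Added to the Phenyl of Compound 2

The source may report more compounds than this note shows. Statements on the series, on what has been measured and on what is new or still open speak of the compounds shown alone.

Compound 1, `Brc1cn2ccnc2c(-c2ccc3ncn(C4CCCCC4)c3c2)n1`: 6.47%
Compound 2, `c1ccc(-c2cn3ccnc3c(-c3ccc4ncn(C5CCCCC5)c4c3)n2)cc1`: 28.8%

Of the compounds shown here, two have been measured in a functional assay on SN12C cells (Homo sapiens) for inhibition, read by sulforhodamine B assay, with a stated time of 48 h, tested at 10 uM; a higher number here means more inhibition at the concentration tested (going by the name of the read-out), a lower number less inhibition. Among the measured compounds shown here, compound 2 gives the higher of the two numbers; its nearest neighbour is compound 1, and the single measured step, a number 22.3 percentage points higher from compound 1 to compound 2 (beyond the scatter), lies beyond the scatter.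

Compound 3, `COc1ccc(-c2cn3ccnc3c(-c3ccc4ncn(C5CCCCC5)c4c3)n2)cc1`, is next. It differs from compound 2 by methoxy in place of hydrogen on an aromatic carbon. For the measured compounds named here, no measured step bears directly on this change: the only step known exchanges bromo for phenyl, and nothing shows what a methoxy on that phenyl does here. Compound 2 therefore remains the only anchor, and the expected step, a number 3.2 percentage points higher from compound 2 to compound 3 (within the scatter), is a small one, not beyond the scatter in either direction. Compound 3 is estimated at 32%, with a range from 12% to 55%.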

Compound 3, a percentage reported as inhibition, at one concentration (the size of the read-out at that concentration, not a potency): 63.6%
Beside the measured number, compound 3's estimate is 31.6 percentage points below it, outside the stated range (above it).
By their numbers in this assay, from the lowest: compound 1; then compound 2; then compound 3.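

In this assay the change from phenyl to 4-methoxyphenyl gives a number 34.8 percentage points higher from compound 2 to compound 3 (beyond the scatter), which shows that a methoxy para to a large group can change the read-out by a large margin. Measured against the bromo compound, the exchange for 4-methoxyphenyl gives a number 57.1 percentage points higher from compound 1 to compound 3 (beyond the scatter), so the outcome at this position depends on what the added ring carries as well as on the ring being present. Nothing available here accounts for the size of this gain.

The compounds shown leave open whether the gain belongs to methoxy itself or would also come with a hydroxyl, an amine or a longer ethoxy chain in its place. They also leave open what a methoxy would do elsewhere on that ring.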